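Swapping the Chain Terminus of a Catechol Vinyl Sulfone

A few compounds are considered here, and "the series" means these few. Any claim that something is new, unique, unknown or untested is made for them only; others in the source may bear on it.

Compound 1 `O=S(=O)(/C=C/c1ccc(O)c(O)c1)CCCc1ccccc1`: 11500 nM
Compound 2 `CCCCCCCCS(=O)(=O)/C=C/c1ccc(O)c(O)c1`: 6400 nM
Compound 3 `O=S(=O)(/C=C/c1ccc(O)c(O)c1)CCCC1CCCCC1`: 7900 nM

In a functional assay, read by fluorescence and spectrophotometry, with a stated time of 1 h (a lower number here means that less compound is needed, a higher number that more compound is needed for the effect), the three measured compounds share one core and differ only in the group sitting on a saturated chain carbon, three bonds along the chain from a sulfonyl sulfur. Compound 3 holds the second highest of the three numbers. Its nearest neighbour is compound 2, with a 1.2-fold higher number from compound 2 to compound 3 (0.09 log units; within the scatter), and its furthest is compound 1, with a 1.5-fold lower number from compound 1 to compound 3 (0.16 log units; within the scatter); the remaining step, a 1.8-fold lower number from compound 1 to compound 2 (0.25 log units; within the scatter), is also within the scatter.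

Compound 4 `O=S(=O)(/C=C/c1ccc(O)c(O)c1)CCCCCCCCCO` is the next member of the series. Relative to compound 3 the change is 6-hydroxyhexyl in place of cyclohexyl on a saturated chain carbon, three bonds along the chain from a sulfonyl sulfur. For the measured compounds named here, none of the measured steps involves a group carrying a hydrogen-bond donor or acceptor at this position, so the only guidance is that the three exchanges of phenyl, pentyl and cyclohexyl all stayed within the scatter. The step from compound 3 to compound 4 is therefore expected to be small, a 1.0-fold higher number from compound 3 to compound 4 (0.01 log units; within the scatter), with a wider range to allow for the unfamiliar hydroxyl. In this assay compound 4 is estimated at 8000 nM, between 3000 nM and 22000 nM.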

Compound 4, half-maximal effective concentration: 7500 nM
Estimate against measurement, compound 4: 1.1-fold (0.03 log units) above; low and high end bracket the measured number.
By their numbers in this assay, from the lowest: compounds 2, 4, 3 and 1 (each within the scatter of the next).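

In this assay, 6-hydroxyhexyl brings 1 hydrogen-bond donor and 1 hydrogen-bond acceptor to a place where the earlier groups carried neither, yet the result is only a 1.1-fold lower number from compound 3 to compound 4 (0.02 log units; within the scatter). The comparisons with the other two compounds read the same way, with a 1.2-fold higher number from compound 2 to compound 4 (0.07 log units; within the scatter), for hydroxymethyl in place of hydrogen on a saturated chain carbon, eight bonds along the chain from a sulfonyl sulfur, and a 1.5-fold lower number from compound 1 to compound 4 (0.19 log units; within the scatter). Adding a hydroxyl to this chain therefore gives no separation from the phenyl, pentyl or cyclohexyl compounds, and nothing available gives a reason for this.

No step shown at this position lies beyond the scatter. Going by these compounds, it remains open whether an amine, a carboxylic acid or a longer chain on that saturated chain carbon would produce such a step.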